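The source may hold more compounds than are shown below. What is called first, only, known or untested is meant among the compounds shown, and "the series" means these compounds.

Compound 3 `CCC(Sc1nc(N)c2cnn(-c3ccccc3)c2n1)C(N)=O` gives 1.56 nM in an assay for displacement of a labelled ligand from adenosine receptor A1 (Rattus norvegicus) (on this read-out higher numbers stand for weaker inhibition and lower numbers for stronger inhibition), the lowest of the three numbers in hand; compound 2 `CCCC(Sc1nc(SC)c2cnn(-c3ccccc3)c2n1)C(N)=O` gives 7.55 nM and compound 1 `CCC(Sc1nc(S)c2cnn(-c3ccccc3)c2n1)C(N)=O` gives 155 nM. Compound 4 `CCC(Sc1nc(SC)c2cnn(-c3ccccc3)c2n1)C(N)=O` is compound 3 with methylsulfanyl in place of amino on an aromatic carbon. Among the compounds with values here, the one measured step at this position is a 99-fold lower number from compound 1 to compound 3 (2.00 log units; beyond the scatter), a large drop that came with amino arriving in place of sulfanyl; taking the amino away again is expected to move the number back up, though compound 2 at 7.55 nM suggests a stop well short of compound 1. A step of a 9.6-fold higher number from compound 3 to compound 4 (0.98 log units; beyond the scatter) is therefore expected in this assay, towards a higher number. Compound 4 is estimated at 15 nM, with a likely range from 4 nM to 60 nM.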

Compound 4, inhibition constant: 8.4 nM
Compound 4: middle estimate off by 1.8-fold (0.25 log units), on the high side, and the stated range covers the measured number.
By their numbers in this assay, from the lowest: compound 3; then compounds 2 and 4 (each within the scatter of the next); then compound 1.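

In this assay, within the data shown here, methylsulfanyl in place of amino costs only a modest step (a 5.4-fold higher number from compound 3 to compound 4 (0.73 log units; beyond the scatter)), so amino is not the only group here that gives a low number. A methyl on the sulfur alone gives a large drop (an 18-fold lower number from compound 1 to compound 4 (1.27 log units; beyond the scatter)), while removing a methyl from the saturated chain leaves no readable difference (a 1.1-fold higher number from compound 2 to compound 4 (0.05 log units; within the scatter)). Nothing measured here explains these steps. Open, going by these compounds, is how a methoxy or methylamino group would compare at this position, and whether an ethyl on the sulfur would keep the number low.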